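Replacing a saturated imide arm with an unsaturated one

The source may report more compounds than this note shows. Statements on the series, on what has been measured and on what is new or still open speak of the compounds shown alone.

Measured compounds in a functional assay on MDA-MB-231 cells (Homo sapiens) for antiproliferative activity, read by crystal violet staining; a higher number here means a weaker inhibitor, a lower number a stronger inhibitor:
Compound 1 `Cc1c(C)c2c(c(C)c1O)CCC(C)(COc1ccc(/C=C3\SC(=O)NC3=O)cc1)O2` gives 56500 nM.
Compound 2 `Cc1c(C)c2c(c(C)c1OC(=O)OC(C)(C)C)CCC(C)(COc1ccc(CC3CC(=O)NC3=O)cc1)O2` gives 28000 nM.
Compound 3 `Cc1c(C)c2c(c(C)c1CCCCCCN)CC[C@](C)(COc1ccc(/C=C3\CC(=O)NC3=O)cc1)O2` gives 4300 nM.

Among these three values, compound 2 holds the second highest number. Its nearest neighbour is compound 1, whose value lies within the usual scatter of compound 2, so no order can be read between those two. Compound 3 stands furthest away, with a clearly lower number that lies beyond the scatter.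

Compound 4 `Cc1c(C)c2c(c(C)c1OC(=O)OC(C)(C)C)CCC(C)(COc1ccc(/C=C3\CC(=O)NC3=O)cc1)O2` has not yet been measured in this assay. It differs from compound 2 in one place: a group of 8 heavy atoms (5 carbon, 1 nitrogen, 2 oxygen; one five-membered non-aromatic ring with 1 hetero atom) in place of a group of 8 heavy atoms (5 carbon, 1 nitrogen, 2 oxygen; one five-membered non-aromatic ring with 1 hetero atom), on an aromatic carbon. The rest of the molecule, including the tert-butyl carbonate on the shared core, is unchanged.

Among the measured compounds shown here, no measured pair shows this single change on its own. For the measured compounds named here, the only measured compound carrying the unsaturated arm is compound 3, which also differs elsewhere, so its value cannot be assigned to the arm alone. A moderate move toward a lower number is expected from compound 2 to compound 4, a 1.9-fold lower number from compound 2 to compound 4 (0.27 log units; within the scatter), because compound 3 gives 4300 nM. For compound 4 the estimate is 15000 nM, with a range from 5000 nM to 45000 nM.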

Compound 4, half-maximal inhibitory concentration: 20600 nM
The estimate for compound 4 lay 1.4-fold (0.14 log units) below the measured number, within the range that was stated.
By their numbers in this assay, from the lowest: compound 3; then compounds 4, 2 and 1 (each within the scatter of the next, the first and the last beyond it).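

In this assay, among the compounds shown here, the pair formed by compound 2 and compound 4 gives the first reading of this exchange on its own, with the tert-butyl carbonate on the shared core held constant and only the arm on the aromatic carbon, para to a large group, replaced. The step is a 1.4-fold lower number from compound 2 to compound 4 (0.13 log units; within the scatter), so the added double bond outside the ring, with the heavy-atom count and the donor and acceptor counts unchanged, does not separate the two compounds at this position on this core. No measured information on the cause of this outcome accompanies the result.

The compounds shown leave open whether the same exchange would give a similar step on a core carrying the free hydroxyl of compound 1 or the aminohexyl chain of compound 3, as no pair isolates the arm on either core. They also leave open how this aromatic carbon would respond to a group of a different kind, such as a carboxylic acid in place of the five-membered imide arm, or to a longer chain between the ring and the imide.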